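A Halogen Swap on the Ketone Aryl Group

The compounds below may be only part of what the source reports. "The series", "measured", "known", "first", "only" and "open" are said of these compounds alone.

Going by the values given here, compound 2 `Cc1ccc(OC(=O)c2ccccc2)c(C(=O)c2cccc(F)c2)c1` stands at one end of the two numbers measured so far: in a functional assay on the whole organism (strain Albino) for inhibition, with Rattus norvegicus as the target, read by paw edema (a lower number here means that less compound is needed, a higher number that more compound is needed for the effect), compound 2 gives 75.5 mg/kg, while compound 1 `Cc1ccc(C(=O)c2cc(C)ccc2OC(=O)c2ccc(Cl)cc2)cc1` gives 57.3 mg/kg, and the gap between them lies within the scatter of the method. Compound 3 `Cc1ccc(OC(=O)c2ccccc2)c(C(=O)c2ccc(Cl)cc2)c1` differs from compound 2 in one place: 4-chlorophenyl in place of 3-fluorophenyl on a carbonyl carbon. Among the compounds with values here, no measured pair carries this same change, so nothing here points in a direction. Compound 3 is therefore expected to stay close to its parent, with the step of a 1.2-fold lower number from compound 2 to compound 3 (0.09 log units; within the scatter) estimated as no larger than the scatter. Compound 3 is estimated at 62 mg/kg, within 30 mg/kg to 130 mg/kg.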

Compound 3, dose for half-maximal effect: 77.9 mg/kg
The estimate for compound 3 lay 1.3-fold (0.10 log units) below the measured number; the range from low to high includes it.
By their numbers in this assay, from the lowest: compounds 1, 2 and 3 (each within the scatter of the next).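

In this assay, going by these compounds alone, 4-chlorophenyl in place of 3-fluorophenyl on a carbonyl carbon gives a 1.0-fold higher number from compound 2 to compound 3 (0.01 log units; within the scatter) and so is the first step read at this position. With this single pair, the two aryl groups cannot be told apart in this measurement. Nothing measured here bears on why this is so.

The compounds shown leave open whether an unsubstituted phenyl, a pyridine or a phenyl carrying a carboxylic acid on this carbonyl carbon would move the number beyond the scatter. This single step cannot say whether the same swap would behave alike on another core.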